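This account rests on a few compounds, and the source may have more. Where it says the series, first, only, none or still open, it means among the compounds named here.

Working notes on the series. Compound 1 `CC(=O)N1N=C(c2ccc(F)cc2)CC1c1cn(-c2ccccc2)nc1-c1cccc([N+](=O)[O-])c1` in a functional assay on the whole organism (Tail) with Rattus norvegicus as the target, in the tail flick test, with a stated time of 60 min, at a dose of 25 mg/kg by the oral route (a lower number here means less inhibition, a higher number more inhibition at the dose given (going by the name of the read-out)), gives 109%. Compound 2 `CC(=O)N1N=C(c2ccc(F)cc2)CC1c1cn(-c2ccccc2)nc1-c1ccccc1` in this assay gives 35%; the change hydrogen in place of nitro on an aromatic carbon thus made the step of a number 74 percentage points lower from compound 1 to compound 2 (beyond the scatter). Compound 3 `O=[N+]([O-])c1cccc(-c2nn(-c3ccccc3)cc2C2CC(c3ccc(F)cc3)=NN2c2ccccc2)c1` in this assay gives 108%; its core differs from the core of compound 1 by phenyl in place of acetyl on an amine nitrogen in a ring, and the step of a number 1 percentage points lower from compound 1 to compound 3 (within the scatter) shows the two cores as interchangeable here. Compound 4 `Fc1ccc(C2=NN(c3ccccc3)C(c3cn(-c4ccccc4)nc3-c3ccccc3)C2)cc1` has not yet been measured. It differs from compound 3 by hydrogen in place of nitro on an aromatic carbon, the same change that turned compound 1 into compound 2, at the same place. On that basis a step of about the size of a number 74 percentage points lower from compound 1 to compound 2 (beyond the scatter) is expected, namely a number 73 percentage points lower from compound 3 to compound 4 (beyond the scatter), because the value of compound 3 108% matches that of compound 1 closely. Compound 4 is therefore estimated at 35%, expected between 10% and 70%.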

Compound 4, a percentage reported as inhibition, in the whole organism at one dose (the size of the read-out at that dose, not a potency): 35%
Estimate against measurement, compound 4: no gap at the digits printed; low and high end bracket the measured number.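

Hydrogen in place of nitro gives a number 73 percentage points lower from compound 3 to compound 4 (beyond the scatter), and in this assay this step agrees with the one seen on the core of compound 1: the same change on two cores in this assay, a number 74 percentage points lower (beyond the scatter) from compound 1 to compound 2 and a number 73 percentage points lower (beyond the scatter) from compound 3 to compound 4, 1 percentage points apart, within the scatter of two such steps Phenyl in place of acetyl gives no change at the digits printed from compound 2 to compound 4 (within the scatter), with or without the nitro group: the same change on two cores in this assay, a number 1 percentage points lower (within the scatter) from compound 1 to compound 3 and no change at the digits printed (within the scatter) from compound 2 to compound 4, 1 percentage points apart, within the scatter of two such steps This shows that the nitro step carries over between these two cores at the single dose and time tested, but it does not show that it would carry over to any other core, nor does it explain why the step is so large.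

On these data alone, it remains open whether another group at the same place, such as a nitrile, an amine or a carboxylic acid, would behave like nitro or like hydrogen. As far as these compounds go, it also remains open whether a longer chain on the ring nitrogen would fit the match between acetyl and phenyl.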